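A few compounds are considered here, and "the series" means these few. Any claim that something is new, unique, unknown or untested is made for them only; others in the source may bear on it.

Measured in an ADME assay on HOS cells (Homo sapiens) for cytotoxicity; a lower number here means that less compound is tolerated, a higher number that more compound is tolerated:
- compound 1 `CN(Cc1nc2ccccc2n1CC1CCNC1)C1CCCc2cccnc21`: 7700 nM
- compound 2 `CN1CCCC(Cn2c(CN(C)C3CCCc4cccnc43)nc3ccccc32)C1`: 3000 nM
- compound 3 `CN(Cc1nc2ccccc2n1CC1CNC1)C1CCCc2cccnc21`: 15000 nM

Compound 3 is level with compound 1 within the scatter, a 1.9-fold higher number from compound 1 to compound 3 (0.29 log units; within the scatter), and clear of compound 2, a 5.0-fold higher number from compound 2 to compound 3 (0.70 log units; beyond the scatter).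

Compound 4 `CN1CCCCC1CCn1c(CN(C)C2CCCc3cccnc32)nc2ccccc21` is the next to read. The change is (1-methylpiperidin-2-yl)methyl in place of azetidin-3-yl on a saturated chain carbon bound to an aromatic nitrogen.

Among the measured compounds shown here, the closest precedent is compound 2, which carries 1-methylpiperidin-3-yl, so a 5.0-fold higher number from compound 2 to compound 3 (0.70 log units; beyond the scatter) is read in reverse. Also relevant is a 2.6-fold lower number from compound 1 to compound 2 (0.41 log units; beyond the scatter), which points the same way. Both are modest. For the measured compounds named here, no measured compound carries (1-methylpiperidin-2-yl)methyl, so the range stays wide.

The expected step is modest and downward, a 5.0-fold lower number from compound 3 to compound 4 (0.70 log units; beyond the scatter).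

For compound 4 the estimate is 3000 nM, with an expected range of 1200 nM to 8000 nM.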

Compound 4, half-maximal cytotoxic concentration: 4900 nM
Compound 4: the middle estimate sits 1.6-fold (0.21 log units) below what was measured; measured number inside the range.
By their numbers in this assay, from the lowest: compounds 2, 4, 1 and 3 (each within the scatter of the next, the first and the last beyond it).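

In this assay, (1-methylpiperidin-2-yl)methyl on the saturated chain carbon bound to an aromatic nitrogen stays level with the two larger-ring neighbours (a 1.6-fold higher number from compound 2 to compound 4 (0.21 log units; within the scatter); a 1.6-fold lower number from compound 1 to compound 4 (0.20 log units; within the scatter)) and separates only from the azetidin-3-yl compound (a 3.1-fold lower number from compound 3 to compound 4 (0.49 log units; beyond the scatter)). The larger group therefore brings no clear change from 1-methylpiperidin-3-yl or pyrrolidin-3-yl at this position. No supporting measurement explains these steps.

Still open, going by these compounds, is how piperidin-3-yl without the methyl, or 1-methylazetidin-3-yl, would read. Either could help separate ring size from the methyl on the ring nitrogen.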